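The source may report more compounds than this note shows. Statements on the series, on what has been measured and on what is new or still open speak of the compounds shown alone.

Compound 3 `COc1ncc(-c2ccc3nccc(-c4ccc(CN5CCN(C)CC5)cc4)c3c2)cc1NS(=O)(=O)c1ccc(F)cc1F` gives 13.3 nM in a functional assay on A549 cells (Homo sapiens) for cytotoxicity, read by MTT assay, with a stated time of 72 h (on this read-out lower numbers stand for stronger inhibition and higher numbers for weaker inhibition), the lowest of the three numbers recorded so far. Its nearest neighbour is compound 2 `COc1ncc(-c2ccc3nccc(-c4ccc(CN5CCCCC5)cc4)c3c2)cc1NS(=O)(=O)c1ccc(F)cc1F`, which gives 15.5 nM in this assay, and the furthest is compound 1 `CCN(Cc1ccc(-c2ccnc3ccc(-c4cnc(OC)c(NS(=O)(=O)c5ccc(F)cc5F)c4)cc23)cc1)C1CCCCC1`, which gives 20.2 nM; both separations lie within the scatter, so none of the three can be set above the others.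

Compound 4 `COc1ncc(-c2ccc3nccc(-c4ccc(CN5CCN(C(C)C)CC5)cc4)c3c2)cc1NS(=O)(=O)c1ccc(F)cc1F` differs from compound 3 by a single change: isopropyl in place of methyl on an amine nitrogen in a ring.

The measured steps all concern the amine carried on the saturated chain carbon bound to the aromatic carbon. Going a 1.3-fold lower number from compound 1 to compound 2 (0.12 log units; within the scatter), going a 1.5-fold lower number from compound 1 to compound 3 (0.18 log units; within the scatter), and going a 1.2-fold lower number from compound 2 to compound 3 (0.07 log units; within the scatter) each stayed within the scatter, even though the amine itself was exchanged wholesale. Among the measured compounds shown here, no measured step alters the group on the ring nitrogen of the piperazine, so the present change has no direct precedent; what the data do show is that changes in this part of the molecule have so far left the read-out in this assay essentially unmoved.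

On that basis compound 4 is expected to stay close to compound 3, with a 1.1-fold higher number from compound 3 to compound 4 (0.02 log units; within the scatter) as the anticipated step and no movement beyond the scatter. The estimate for compound 4 in this assay is 14 nM, with a range from 6 nM to 32 nM.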

Compound 4, half-maximal inhibitory concentration: 1.9 nM
The estimate for compound 4 lay 7.4-fold (0.87 log units) above the measured number; measured number below the stated range.
By their numbers in this assay, from the lowest: compound 4; then compounds 3, 2 and 1 (each within the scatter of the next).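

The earlier compounds shown here showed no step beyond the scatter, even when the whole amine was exchanged, whereas isopropyl in place of methyl on the amine nitrogen in the ring gives a 7.0-fold lower number from compound 3 to compound 4 (0.85 log units; beyond the scatter) in this assay, so the read-out does respond at this position. The separation also holds against the other two amines, with an 8.2-fold lower number from compound 2 to compound 4 (0.91 log units; beyond the scatter) and an 11-fold lower number from compound 1 to compound 4 (1.03 log units; beyond the scatter), which makes compound 4 the only one of the four whose steps to all the others lie beyond the scatter. Nothing in the data shown gives a measured reason for this step.

On these data alone, whether the step belongs to isopropyl alone or extends to other groups on the same nitrogen stays open: ethyl, cyclopropyl, tert-butyl or a hydroxyethyl chain there would show whether it continues, levels off or reverses. The compounds shown also leave open whether the step carries over to other cell lines, and whether isopropyl would have any such effect on a different amine, such as a piperidine bearing it on a ring carbon.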